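This account rests on a few compounds, and the source may have more. Where it says the series, first, only, none or still open, it means among the compounds named here.

Measured in a functional assay on A549 cells (Homo sapiens) for cytotoxicity, read by MTT assay, with a stated time of 6 days; on this read-out higher numbers stand for an effect only at larger amounts of compound and lower numbers for an effect already at smaller amounts:
Compound 1 `COC(=O)c1c(-c2ccc(O)cc2)oc2cc(OC)ccc2c1=O`: > 25 ug/mL
Compound 2 `CC(=O)Nc1ccc(-c2cc(=O)c3c(OC(C)=O)cc(OC(C)=O)cc3o2)cc1`: 22 ug/mL

The entry for compound 1 in this assay, > 25 ug/mL, is a limit of the assay and not a number. For the measured compounds named here, compound 2, at 22 ug/mL, therefore holds the only true number in this small set, and that number gives the starting point for what follows.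

Compound 3 `CC(=O)Nc1ccc(-c2cc(=O)c3ccc(OC(C)=O)cc3o2)cc1` comes from compound 2 through one change, hydrogen in place of acetoxy on an aromatic carbon, meta to the acetoxy group that remains. Going by the values given here, no measured pair here shows what such a change does in this assay, so no step beyond the usual scatter is expected, in either direction. The expected change is no change at the digits printed from compound 2 to compound 3 (within the scatter). For compound 3 the estimated value is 22 ug/mL, with an expected range of 10 ug/mL to 45 ug/mL.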

Compound 3, concentration for half-maximal effect: 20.5 ug/mL
The estimate for compound 3 lay 1.1-fold (0.03 log units) above the measured number; the range from low to high includes it.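

In this assay, the exchange of acetoxy for hydrogen on this aromatic carbon, meta to the acetoxy group that remains, gives a 1.1-fold lower number from compound 2 to compound 3 (0.03 log units; within the scatter). For the compounds shown here, this is the first reading of this position, and it shows that the read-out stays at the same level without this acetoxy group and its 4 heavy atoms. Compound 1 adds nothing to this reading, as its entry is a limit and not a number: the limit of > 25 ug/mL in this assay, at which 1 of the 3 values shown sits.

On these data alone, it remains open whether another group at this position, such as an amine, a hydroxyl group or a longer ester chain, would move the number beyond the scatter. Also open, as far as these compounds go, is whether hydrogen or a hydroxyl group in place of the acetoxy group that remains would change the read-out.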